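The source may hold more compounds than are shown below. What is called first, only, known or untested is meant among the compounds shown, and "the series" means these compounds.

Working notes on the series. Compound 1 `CCOC(=O)/C=C/[C@H](CCC(N)=O)NC(=O)[C@@H]1Cc2ccccc2CN1C(=O)[C@@H](NC(=O)c1cccc(O)c1C)C(C)C` and compound 2 `CCOC(=O)/C=C/[C@H](CCC(N)=O)NC(=O)[C@@H]1Cc2ccccc2CN1C(=O)[C@H](CC(C)C)NC(=O)c1cccc(O)c1C` share one core; compound 2 carries isobutyl in place of isopropyl on a saturated chain carbon bound to an amide-type nitrogen and a carbonyl carbon. In an ADME assay on a cell-free system (plasma, Homo sapiens) for metabolic stability, with Plasma (Rattus norvegicus) as the target, with a stated time of 6 h (a higher number here means that the compound lasts longer, a lower number that the compound disappears faster), compound 1 gives > 6 h, which is a limit of the assay and not a number. In this assay compound 2 gives > 6 h, again a limit. Among the compounds with values here, the step that the two limits leave unreadable from compound 1 to compound 2 therefore cannot be read, and the limit of > 6 h in this assay, at which 2 of the 2 values shown sit, is the whole evidence on hand, so compound 2 stands at that limit together with the only other compound measured.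

Compound 3 `CCOC(=O)/C=C/[C@H](CC(C)C)NC(=O)[C@@H]1Cc2ccccc2CN1C(=O)[C@H](CC(C)C)NC(=O)c1cccc(O)c1C` differs from compound 2 in isopropyl in place of carbamoylmethyl on a saturated chain carbon, two bonds along the chain from an amide-type nitrogen and a double-bonded chain carbon. Within the data shown here, the one measured step bears on it only in showing that exchanging one side chain did not bring the series under the limit. Nothing measured separates a change at this position from that, so the expectation for compound 3 in this assay is a value at or past the same limit, with a step that the limit leaves unreadable from compound 2 to compound 3 expected to stay within the scatter. The estimate for compound 3 is 8 h, between 3 h and 20 h.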

Compound 3, half-life: > 6 h
Compound 3 ended at the assay's limit; the forecaster's own chance of this, stated with the estimate: 75%; the middle value is on the limit's open side.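

In this assay compound 3 gives > 6 h, a limit of the assay and not a number. No step can be read between compound 2 and compound 3, so isopropyl in place of carbamoylmethyl has no readable size here. The compounds shown leave open how long any of them actually lasts, and whether the side chains differ at all: the limit of > 6 h in this assay, at which 3 of the 3 values shown sit.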